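The compounds below may be only part of what the source reports. "The series", "measured", "known", "first", "only" and "open" are said of these compounds alone.

Compound 1 `CCOC(=O)/C=C/c1cnc(Nc2ccc(C#N)cc2)nc1Oc1c(C)cc(C#N)cc1C`: > 227 nM
Compound 2 `C#CCNC(=O)/C=C/c1cnc(Nc2ccc(C#N)cc2)nc1Oc1c(C)cc(C#N)cc1C`: > 222 nM
Compound 3 `Cc1cc(C#N)cc(C)c1Oc1nc(Nc2ccc(C#N)cc2)ncc1/C=C/C(=O)N1CCN(S(C)(=O)=O)CC1`: > 179 nM

In an ADME assay on TZM cells (Homo sapiens) for cytotoxicity, with a stated time of 1 days (on this read-out higher numbers stand for lower toxicity in this test and lower numbers for higher toxicity in this test), compound 3 stands only at a limit, (the limit of > 179 nM in this assay, at which 1 of the 3 values shown sits); it is not a number. Compound 1 also sits at a limit, (the limit of > 227 nM in this assay, at which 1 of the 3 values shown sits). Compound 2 likewise sits at a limit, (the limit of > 222 nM in this assay, at which 1 of the 3 values shown sits). Compound 4 `Cc1cc(C#N)cc(C)c1Oc1nc(Nc2ccc(C#N)cc2)ncc1/C=C/C(=O)N1CCN(S(=O)(=O)C(F)(F)F)CC1` carries one change against compound 3: trifluoromethyl in place of methyl on a sulfonyl sulfur. The measured steps all change the carbonyl substituent, not the sulfonyl, and each is unreadable: a step that the two limits leave unreadable from compound 1 to compound 2, a step that the two limits leave unreadable from compound 1 to compound 3, a step that the two limits leave unreadable from compound 2 to compound 3. They therefore give no readable size in this assay to carry over, and the expected step is a step that the limit leaves unreadable from compound 3 to compound 4, most probably again a limit. Compound 4 is estimated at 300 nM, within 180 nM to 1500 nM.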

Compound 4, half-maximal cytotoxic concentration: > 164 nM
Compound 4 gave a limit, no number; the forecaster's own chance of this, stated with the estimate: 80%; the middle value does not contradict the limit.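

In this assay compound 4 gives > 164 nM, a limit and not a number. For the compounds shown here, compound 3 gives > 179 nM, also a limit, so no step between compound 3 and compound 4 can be read. The compounds shown leave open whether trifluoromethyl in place of methyl on a sulfonyl sulfur changes the half-maximal cytotoxic concentration at all.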